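This account rests on a few compounds, and the source may have more. Where it says the series, first, only, none or still open, it means among the compounds named here.

Compound 3, `COc1n[nH]c2ncc(C#Cc3c(F)ccc(NS(=O)(=O)c4ccc(Cl)cc4)c3F)cc12`, is one of three close analogues built on a shared core and differing only in the substituent on the benzene ring of the sulfonyl group. In an assay on cells for inhibition of mitogen-activated protein kinase kinase kinase 20 (Homo sapiens), read by ADP-Glo, with a stated time of 30 min (a higher number here means a weaker inhibitor, a lower number a stronger inhibitor), compound 3 gives 16.8 nM. The unsubstituted parent compound 1, `COc1n[nH]c2ncc(C#Cc3c(F)ccc(NS(=O)(=O)c4ccccc4)c3F)cc12`, gives 19.2 nM, and a 1.1-fold lower number from compound 1 to compound 3 (0.06 log units; within the scatter). Compound 2, `COc1n[nH]c2ncc(C#Cc3c(F)ccc(NS(=O)(=O)c4cccc(Cl)c4)c3F)cc12`, gives 4.2 nM, so that among these three numbers compound 3 sits second highest, close to compound 1 and well apart from compound 2.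

Compound 4, `COc1n[nH]c2ncc(C#Cc3c(F)ccc(NS(=O)(=O)c4cccc(Br)c4)c3F)cc12`, differs from compound 3 by 3-bromophenyl in place of 4-chlorophenyl on a sulfonyl sulfur. Among the compounds with values here, two measured steps bear on this change. The chlorine moving from the position it holds in compound 3 to the position it holds in compound 2 reads as a 4.0-fold higher number from compound 2 to compound 3 (0.60 log units; beyond the scatter) in reverse, and the gain from adding chlorine at that position is a 4.6-fold lower number from compound 1 to compound 2 (0.66 log units; beyond the scatter). Both point to a lower number when the halogen sits at the position found in compound 2. Bromine is not yet tested at any position, so the size carries added uncertainty. Compound 4 is therefore expected to show a 3.4-fold lower number from compound 3 to compound 4 (0.53 log units; beyond the scatter), giving an estimated 5 nM with a range of 2 nM to 15 nM.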

Compound 4, half-maximal inhibitory concentration: 5 nM
Compound 4: middle estimate and measured number agree at the digits printed, within the range that was stated.
By their numbers in this assay, from the lowest: compounds 2 and 4 (each within the scatter of the next); then compounds 3 and 1 (each within the scatter of the next).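

In this assay, bromo in place of chloro on an aromatic carbon gives a 1.2-fold higher number from compound 2 to compound 4 (0.08 log units; within the scatter), so the two halogens cannot be told apart at the position they share in these compounds. Bromo in place of hydrogen gives a 3.8-fold lower number from compound 1 to compound 4 (0.58 log units; beyond the scatter), which stands alongside a 4.6-fold lower number from compound 1 to compound 2 (0.66 log units; beyond the scatter) for chloro and shows that the earlier gain is not confined to chlorine. The step of a 3.4-fold lower number from compound 3 to compound 4 (0.53 log units; beyond the scatter) changes both the halogen and its position, but since swapping the halogen alone stays within the scatter, the difference among these compounds follows position rather than halogen, and compound 3 is the halogen-bearing compound that shows no gain over compound 1, at a 1.1-fold lower number from compound 1 to compound 3 (0.06 log units; within the scatter).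

Nothing measured here accounts for why the two halogens read alike. As far as these compounds go, whether fluoro, methoxy, an amine or a carboxylic acid in place of the bromo would keep this number remains open.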